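The source may report more compounds than this note shows. Statements on the series, on what has been measured and on what is new or still open speak of the compounds shown alone.

Of the compounds shown here, two have so far been measured in a functional assay on HepG2 cells (Homo sapiens) for inhibition, read by CCK-8 assay, with a stated time of 72 h, tested at 20 uM; on this read-out lower numbers stand for less inhibition of growth and higher numbers for more inhibition of growth at the one concentration tested. Compound 1 `CCOC(=O)/C=C1/C(=O)Nc2ccccc21` gives 90.2%. Compound 2 `CC(C)(C)OC(=O)/C=C1/C(=O)Nc2ccccc21` gives 86.1%; the step of a number 4.1 percentage points lower from compound 1 to compound 2 (within the scatter) lies within the scatter, so compound 2 stands together with compound 1 on this read-out. Compound 3 `CC(C)(C)OC(=O)/C=C1/C(=O)N(Cc2ccccc2)c2ccccc21` carries the change (benzyl in place of hydrogen on an amide-type nitrogen in a ring). For the measured compounds named here, no measured step bears on the amide-type nitrogen in the ring; the only step known alters the ester and stays within the scatter. The expected step is a number 6.1 percentage points lower from compound 2 to compound 3 (within the scatter), with a wide margin. The estimate for compound 3 is 80%, between 55% and 95%.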

Compound 3, percent growth inhibition at one concentration: 88%
Compound 3: middle estimate off by 8 percentage points, on the low side; measured number inside the range.
By their numbers in this assay, from the lowest: compounds 2, 3 and 1 (each within the scatter of the next).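

In this assay, benzyl in place of hydrogen on the amide-type nitrogen in the ring gives a number 1.9 percentage points higher from compound 2 to compound 3 (within the scatter), so with the tert-butyl ester in place, the amide hydrogen is not required for this read-out at the one concentration tested. For the compounds shown here, this is the first information on this nitrogen, as the earlier step bore only on the ester. No available evidence gives a reason for this result.

As far as these compounds go, it remains open whether this nitrogen also accepts a methyl group or a chain ending in an amine, and whether a carboxylic acid can replace the ester. Compounds 1, 2 and 3 stand within the scatter of their neighbours at a single concentration, so these data do not separate them.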